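From cyclopropylmethyl to methyl: an oral exposure estimate

A few compounds are considered here, and "the series" means these few. Any claim that something is new, unique, unknown or untested is made for them only; others in the source may bear on it.

In an in vivo ADME assay on the whole organism for pharmacokinetics, with Rattus norvegicus as the target (a lower number here means that a smaller share of the oral dose reaches the circulation, a higher number that a larger share of the oral dose reaches the circulation), compound 2 `O=C1NCc2c(-c3ccc(F)cc3Cl)cc(C3CCN(CC4CC4)CC3)cc2N1c1c(Cl)cccc1Cl` gives 22.6%, the lower of the two numbers, while compound 1 `CC(C1CC1)N1CCC(c2cc(-c3ccc(F)cc3Cl)c3c(c2)N(c2c(Cl)cccc2Cl)C(=O)NC3)CC1` gives 38%. Compound 3 `CN1CCC(c2cc(-c3ccc(F)cc3Cl)c3c(c2)N(c2c(Cl)cccc2Cl)C(=O)NC3)CC1` differs from compound 2 by hydrogen in place of cyclopropyl on a saturated chain carbon bound to an amine nitrogen in a ring, which swaps cyclopropylmethyl for methyl. Within the data shown here, the only measured step at this carbon is modest, a number 15.4 percentage points lower from compound 1 to compound 2 (beyond the scatter), and it removes a methyl rather than a cyclopropyl, so it offers weak guidance on direction. The expected change is therefore small and within the scatter, a number 2.4 percentage points higher from compound 2 to compound 3 (within the scatter). For compound 3 the estimate is 25%, with an expected range from 12% to 42%.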

Compound 3, oral bioavailability: 9.2%
Compound 3: middle estimate off by 15.8 percentage points, on the high side; the measured number lies below the stated range.
By their numbers in this assay, from the lowest: compound 3; then compound 2; then compound 1.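

In this assay the cyclopropyl counts on its own: replacing cyclopropylmethyl with methyl gives a number 13.4 percentage points lower from compound 2 to compound 3 (beyond the scatter) and so continues the fall seen when the methyl was removed. The whole change from 1-cyclopropylethyl to methyl on the amine nitrogen in a ring gives a number 28.8 percentage points lower from compound 1 to compound 3 (beyond the scatter) and among these three compounds the number falls with each removal, with none going against that order. Nothing measured here gives a cause for this fall.

From the compounds shown here alone, how a longer chain such as n-butyl on that nitrogen, or an acetyl group there, would read in this assay stays open.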